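Swapping the Side Group on Compound 1

The source may hold more compounds than are shown below. What is called first, only, known or untested is meant among the compounds shown, and "the series" means these compounds.

- compound 1 `O=C1NC(O)(CCn2cnc3cc[nH]c3c2=O)C(OCc2ccccc2)=C1OCc1ccccc1` gives 87000 nM
- compound 2 `O=C1O/C(=C\Cn2cnc3cncc(Br)c32)C(OCc2ccccc2)=C1OCc1ccccc1` gives 5700 nM
- compound 3 `O=C1NC(O)(/C=C\n2cc(I)c3c(Cl)ncnc32)C(OCc2ccccc2)=C1OCc1ccccc1` gives > 250000 nM

In a functional assay on CCRF-CEM cells (Homo sapiens) for antiproliferative activity, read by MTT assay, with a stated time of 72 h (a higher number here means a weaker inhibitor, a lower number a stronger inhibitor), compound 1 gives 87000 nM and holds the higher of the two actual numbers, a gap to compound 2 that lies beyond the usual scatter. For compound 3 the reading of > 250000 nM is a limit of the assay and not a number.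

Compound 4 `O=C1NC(O)(CCn2cnc3cncc(Br)c32)C(OCc2ccccc2)=C1OCc1ccccc1` has not been measured yet. It differs from compound 1 in one place, on a saturated chain carbon, two bonds along the chain from a saturated ring carbon: a group of 10 heavy atoms (6 carbon, 3 nitrogen, 1 bromine; one five-membered aromatic ring with 2 hetero atoms, one six-membered aromatic ring with 1 hetero atom) in place of a group of 10 heavy atoms (6 carbon, 3 nitrogen, 1 oxygen; one five-membered aromatic ring with 1 hetero atom, one six-membered aromatic ring with 2 hetero atoms), on a saturated chain carbon, two bonds along the chain from a saturated ring carbon. Within the data shown here, no measured pair shows this change alone, so any expectation is uncertain. The entering group also occurs in compound 2 at 5700 nM, although that compound differs elsewhere too. A moderate fall in this assay is therefore expected, beyond the scatter but not the full gap to compound 2. The estimated step is a 2.9-fold lower number from compound 1 to compound 4 (0.46 log units; beyond the scatter) and it points toward a stronger inhibitor. Compound 4 is estimated at 30000 nM, within a range of 7000 nM to 130000 nM as expected limits of the estimate.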

Compound 4, half-maximal inhibitory concentration: 25000 nM
For compound 4 the middle estimate is 1.2-fold (0.08 log units) above the measured one, and the stated range covers the measured number.
By their numbers in this assay, from the lowest: compound 2; then compound 4; then compound 1. At a limit, above all of these: compound 3.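

Among these compounds, this is the first comparison in which only the side group on the saturated chain carbon changes while the rest of the molecule stays the same. In this assay it gives a 3.5-fold lower number from compound 1 to compound 4 (0.54 log units; beyond the scatter), so the side group alone moves the number beyond the scatter, toward a stronger inhibitor. The entering group brings a bromine and no hydrogen-bond donor, and the leaving group takes away an oxygen and a hydrogen-bond donor, all in one step, and nothing measured here bears on which of these differences matters.

As far as these compounds go, what remains open is whether the bromine itself is needed, which an amine or a plain hydrogen in its place would test. Also open, from the compounds shown here alone, is how a longer chain carrying the same entering group would behave.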